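This account rests on a few compounds, and the source may have more. Where it says the series, first, only, none or still open, it means among the compounds named here.

Working notes on the series. Two compounds have numbers in a functional assay for activation of Alpha-1A adrenergic receptor (Homo sapiens) (a lower number here means that less compound is needed, a higher number that more compound is needed for the effect), so far. Compound 1 `CS(=O)(=O)c1ccccc1NCc1c[nH]cn1` gives 126 nM in this assay. Compound 2 `c1ccc(N2CCCCC2)c(NCC2=NCCN2)c1` gives 12.6 nM in this assay, the lowest of the two numbers; the gap to compound 1 is beyond the scatter. Going by the values given here, no pair that differs in a single place has been measured, so no step is known yet.

Compound 3 `c1ccc(N2CCCCC2)c(NCc2c[nH]cn2)c1` is the next compound to be measured in this assay. Relative to compound 2 the change is a group of 5 heavy atoms (3 carbon, 2 nitrogen; one five-membered aromatic ring with 2 hetero atoms) in place of a group of 5 heavy atoms (3 carbon, 2 nitrogen; one five-membered non-aromatic ring with 2 hetero atoms), on a saturated chain carbon bound to a nitrogen on an aromatic ring. Among the compounds with values here, the only other compound carrying the 1H-imidazol-4-yl group is compound 1, whose value in this assay is 126 nM, but it also differs elsewhere, so it gives no clean guide. The expectation is a step of a 4.8-fold higher number from compound 2 to compound 3 (0.68 log units; beyond the scatter) toward a higher number, modest but beyond the scatter. For compound 3 the estimate in this assay is 60 nM, within 15 nM to 250 nM.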

Compound 3, half-maximal effective concentration: 50.1 nM
The estimate for compound 3 lay 1.2-fold (0.08 log units) above the measured number; the measured number falls inside the stated range.
By their numbers in this assay, from the lowest: compound 2; then compound 3; then compound 1.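

In this assay, 1H-imidazol-4-yl in place of the five-membered non-aromatic ring, on a saturated chain carbon bound to a nitrogen on an aromatic ring, gives a 4.0-fold higher number from compound 2 to compound 3 (0.60 log units; beyond the scatter) and so shows that this position responds to the change, with the non-aromatic ring giving the lower number. Going by these compounds alone, with 1H-imidazol-4-yl held constant, piperidin-1-yl in place of methylsulfonyl on an aromatic carbon gives a 2.5-fold lower number from compound 1 to compound 3 (0.40 log units; beyond the scatter) and so provides the first clean reading at this second place. No measurement at hand accounts for either step.

The compounds shown leave open whether the step from methylsulfonyl to piperidin-1-yl keeps its size when the non-aromatic ring replaces 1H-imidazol-4-yl. They also leave open how a methoxy group or a dimethylamino group on that aromatic carbon, or a longer chain to either five-membered ring, would compare.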